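Isopropylamine to methanesulfonamide on the core of compound 1

The source may hold more compounds than are shown below. What is called first, only, known or untested is meant among the compounds shown, and "the series" means these compounds.

Compound 1 `CC(C)NCc1ccc(-c2c3ncn(CC4(O)CCN(Cc5ccc(-c6ccco6)cc5Cl)CC4)c(=O)c3nn2C)cc1` is the strongest inhibitor among the three measured compounds: in an assay on isolated protein for inhibition of ubiquitin carboxyl-terminal hydrolase 7 (Homo sapiens), with stated times of 30 min and 2 h (a lower number here means a stronger inhibitor, a higher number a weaker inhibitor), compound 1 gives 29.1 nM. Compound 2 `Cn1nc2c(=O)n(CC3(O)CCN(Cc4ccc(-n5ccnc5)cc4Cl)CC3)cnc2c1-c1ccc(CN)cc1` gives 228 nM and compound 3 `Cn1nc2c(=O)n(CC3(O)CCN(Cc4ccc(-c5ccc[nH]5)cc4Cl)CC3)cnc2c1-c1ccc(CN)cc1` gives 193 nM; both stand beyond the scatter above compound 1. Within the data shown here, the only single-point step among the measured compounds, a 1.2-fold lower number from compound 2 to compound 3 (0.07 log units; within the scatter), concerns the aryl group on an aromatic carbon and not the amine, and it lies within the scatter.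

Compound 4 `Cn1nc2c(=O)n(CC3(O)CCN(Cc4ccc(-c5ccco5)cc4Cl)CC3)cnc2c1-c1ccc(CNS(C)(=O)=O)cc1` keeps everything of compound 1 except the amine end: methylsulfonyl in place of isopropyl on an amine nitrogen. Among the measured compounds shown here, no measured pair shows this change on its own. Compounds 2 and 3 carry a free aminomethyl group and sit well above compound 1, but they also differ from compound 1 in the aryl group, so their values do not separate the two changes. The aryl step from compound 2 to compound 3 was small, which weakly suggests that the amine end carries more of the difference, though this rests on a single pair. For compound 4 a moderate rise in the number, beyond the scatter, is therefore expected, a 2.9-fold higher number from compound 1 to compound 4 (0.47 log units; beyond the scatter). The estimate for compound 4 is 85 nM, within 25 nM to 300 nM.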

Compound 4, half-maximal inhibitory concentration: 65.3 nM
The estimate for compound 4 lay 1.3-fold (0.11 log units) above the measured number; the range from low to high includes it.
By their numbers in this assay, from the lowest: compound 1; then compound 4; then compounds 3 and 2 (each within the scatter of the next).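

Among these compounds, the step from isopropyl to methylsulfonyl on the amine nitrogen is the first change at this end of the molecule that can be read on its own, with the rest of compound 1 held fixed: in this assay it gives a 2.2-fold higher number from compound 1 to compound 4 (0.35 log units; beyond the scatter). The step lies beyond the scatter but is modest, so this position accepts a methanesulfonamido group, with its two hydrogen-bond acceptors and no net charge, in place of an isopropylamino group, and compound 4 still gives 65.3 nM. Nothing measured here explains why the change costs this much and no more.

On these data alone, compounds 2 and 3 carry a free aminomethyl group but also differ from compound 1 in the aryl group, so the effect of a primary amine at this position on the aryl group of compound 1 stays open, as does whether the same step would hold with the aryl groups of compounds 2 and 3. As far as these compounds go, how an acetamide, a carboxylic acid or a longer chain on this nitrogen would compare also remains unknown.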